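Replacing an Arylamino Group on an Antiproliferative Compound

The source may report more compounds than this note shows. Statements on the series, on what has been measured and on what is new or still open speak of the compounds shown alone.

For the measured compounds named here, in a functional assay on A-375 cells (Homo sapiens) for antiproliferative activity, read by CCK-8 assay, with a stated time of 72 h (a lower number here means a stronger inhibitor, a higher number a weaker inhibitor), compound 1 (`Cc1ccc(Nc2nc(Cl)nc3c2ncn3Cc2ccc(C(=O)Nc3ccccc3N)cc2)cc1`) gives 470 nM and holds the lower of the two numbers so far. Compound 2 (`Nc1ccccc1NC(=O)c1ccc(CNc2nc(Cl)nc3c2ncn3C2CCCC2)cc1`) gives 2790 nM and sits beyond the scatter from it. Compound 3 (`CN1CCN(c2nc(Cl)nc3c2ncn3Cc2ccc(C(=O)Nc3ccccc3N)cc2)CC1`) keeps the shared core of compound 1 but has 4-methylpiperazin-1-yl in place of (4-methylphenyl)amino on an aromatic carbon. Going by the values given here, no measured pair shows this swap alone, so the expectation is rough. A weakening beyond the scatter is expected in this assay, estimated as a 3.2-fold higher number from compound 1 to compound 3 (0.50 log units; beyond the scatter) (a moderate step). Compound 3 is estimated at 1500 nM (expected range 400 nM to 6000 nM).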

Compound 3, half-maximal inhibitory concentration: 1600 nM
Estimate against measurement, compound 3: 1.1-fold (0.03 log units) below; low and high end bracket the measured number.
By their numbers in this assay, from the lowest: compound 1; then compounds 3 and 2 (each within the scatter of the next).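

In this assay, for the compounds shown here, this is the first direct comparison at this position: 4-methylpiperazin-1-yl in place of (4-methylphenyl)amino gives a 3.4-fold higher number from compound 1 to compound 3 (0.53 log units; beyond the scatter), so the group on this aromatic carbon affects the read-out. The swap takes away the six-membered aromatic ring of carbon only and the hydrogen-bond donor, yet compound 3 still gives 1600 nM. As far as these compounds go, it remains open whether a morpholin-4-yl group or an unsubstituted phenylamino group would track compound 1 or compound 3. Nothing available here explains the step.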